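Changing the group on the carbonyl carbon of a shared core

The source may hold more compounds than are shown below. What is called first, only, known or untested is meant among the compounds shown, and "the series" means these compounds.

Measured compounds:
compound 1 `Cc1nc(S(C)(=O)=O)ccc1Oc1ncnc(OC2CCN(C(=O)OC(C)F)CC2)c1F` gives 68%
compound 2 `Cc1nc(S(C)(=O)=O)ccc1Oc1ncnc(OC2CCN(C(=O)C3(F)CCC3)CC2)c1F` gives 91%

Both values come from a functional assay on isolated protein for inhibition of Glucose-dependent insulinotropic receptor (Rattus norvegicus), read by HTRF and cAMP accumulation; a higher number here means a larger maximal response, a lower number a smaller maximal response. Within the data shown here, compound 2 stands highest of the two numbers, and its nearest neighbour is compound 1, reached through the single measured step of a number 23 percentage points higher from compound 1 to compound 2 (beyond the scatter). Compound 3 `CCc1cnc(C(=O)N2CCC(Oc3ncnc(Oc4ccc(S(C)(=O)=O)nc4C)c3F)CC2)nc1` is not yet measured in this assay. It differs from compound 2 by a group of 8 heavy atoms (6 carbon, 2 nitrogen; one six-membered aromatic ring with 2 hetero atoms) in place of a group of 5 heavy atoms (4 carbon, 1 fluorine; one four-membered non-aromatic ring of carbon only), on a carbonyl carbon.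

Among the measured compounds shown here, only the step from compound 1 to compound 2 bears on this change, and only loosely: it was a modest rise when a different group entered at the same carbonyl carbon. The entering group here is unlike either, so no direction can be read from the data. For the measured compounds named here, compound 3 is therefore expected near the middle of the two known numbers, at 82%, with a range from 62% to 100%. The step implied by this estimate is a number 9 percentage points lower from compound 2 to compound 3 (within the scatter), expected to stay within the usual scatter.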

Compound 3, largest response reached (reported as efficacy), in percent of the reference or control that the assay uses: 80%
Compound 3: the middle estimate sits 2 percentage points above what was measured, and the stated range covers the measured number.
By their numbers in this assay, from the lowest: compound 1; then compound 3; then compound 2.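

In this assay, among these compounds, placing 5-ethylpyrimidin-2-yl on the carbonyl carbon shows that this position can carry an aromatic ring with hetero atoms, the only such group among the three, and still give a response that lies between the other two, with a number 11 percentage points lower from compound 2 to compound 3 (beyond the scatter) and a number 12 percentage points higher from compound 1 to compound 3 (beyond the scatter). The three numbers also do not follow the count of heavy atoms in the group, since compound 3 has the largest group yet compound 2 gives the highest number. No measurement here accounts for this order.

The compounds shown leave open how much of the response of compound 3 depends on the ethyl group of 5-ethylpyrimidin-2-yl. They also leave open whether an amine or a longer chain on the same carbonyl carbon would fall within the range of these three groups.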